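The source may report more compounds than this note shows. Statements on the series, on what has been measured and on what is new or still open speak of the compounds shown alone.

Notes on the series in an assay on HEK293 cells for antagonist activity at Voltage-dependent L-type calcium channel subunit alpha-1D (Rattus norvegicus), read by FLIPR; a lower number here means a stronger inhibitor, a higher number a weaker inhibitor. Compound 1 `COC(=O)C1=C(C(C)C)NC(=O)NC1c1cccc([N+](=O)[O-])c1` reaches only a limit here, > 100000 nM. Compound 2 `COC(=O)C1=C(C(C)C)NC(=O)N(C(=O)C(C)C)C1c1cccc([N+](=O)[O-])c1` likewise gives a limit, > 100000 nM. The step that the two limits leave unreadable from compound 1 to compound 2 is therefore unreadable, both ends resting on (the limit of > 100000 nM in this assay, at which 2 of the 3 values shown sit). Within the data shown here, compound 3 `COC(=O)C1=C(C)N=C(SC)NC1c1cccc([N+](=O)[O-])c1` is the one compound with a number in this assay, 10600 nM. Compound 4 `COC(=O)C1=C(C)N=C(SC)N(C(=O)OC(C)C)C1c1cccc([N+](=O)[O-])c1` differs from it by isopropoxycarbonyl in place of hydrogen on an amine nitrogen in a ring. Among the measured compounds shown here, no measured step reads on this change: the only comparison of a substituted with an unsubstituted ring nitrogen, between compound 1 and compound 2, is left unreadable by the limits. The expectation for compound 4 is therefore a step of a 1.1-fold lower number from compound 3 to compound 4 (0.03 log units; within the scatter) within the scatter, with wide uncertainty. Compound 4 is estimated at 10000 nM, between 2500 nM and 40000 nM.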

Compound 4, half-maximal inhibitory concentration: 5580 nM
For compound 4 the middle estimate is 1.8-fold (0.25 log units) above the measured one; low and high end bracket the measured number.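

Here a 1.9-fold lower number from compound 3 to compound 4 (0.28 log units; within the scatter) is the first readable step for a substituent on a ring nitrogen in this series. At this amine nitrogen in a ring, isopropoxycarbonyl in place of hydrogen therefore gives a number within the scatter of the unsubstituted compound, so this position accepts the group without a readable loss. Nothing measured here gives a cause for this step.

Going by these compounds, whether an acetyl group, a longer chain or an amine-bearing chain on this nitrogen would move the number beyond the scatter remains open. So does whether any substituent here can give a clearly stronger inhibitor.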